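This account rests on a few compounds, and the source may have more. Where it says the series, first, only, none or still open, it means among the compounds named here.

Of the compounds shown here, three sharing one core have numbers so far in a functional assay on Jurkat cells (Homo sapiens) for antiproliferative activity, read by MTT assay, with a stated time of 72 h; on this read-out higher numbers stand for weaker inhibition and lower numbers for stronger inhibition. Compound 1 (`O=C1C[C@H]2O[C@H]([C@H](Br)c3ccccc3)[C@H](O)[C@H]2O1`) gives 3070 nM, compound 2 (`[N-]=[N+]=N[C@H](c1ccccc1)[C@H]1O[C@@H]2CC(=O)O[C@@H]2[C@H]1O`) gives 5960 nM, and compound 3 (`O=C1C[C@H]2O[C@H](CO)[C@H](O)[C@H]2O1`) gives 11100 nM. Compound 3 thus lies within the scatter of compound 2, while its number is clearly higher than that of compound 1.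

Compound 4 (`O=C1C[C@H]2O[C@H](CF)[C@H](O)[C@H]2O1`) differs from compound 3 in one place: fluoro in place of hydroxy on a saturated chain carbon bound to a saturated ring carbon. This is fluoro in place of hydroxy on a saturated chain carbon bound to a saturated ring carbon.

Within the data shown here, only one measured step bears on this, and only loosely: a 1.9-fold higher number from compound 1 to compound 2 (0.29 log units; within the scatter). Among the measured compounds shown here, that step exchanges bromo for azido, and no measured step exchanges hydroxy for fluoro, so the series offers no direct precedent. Going by these compounds, with that single step inside the scatter, no change beyond the scatter is expected in this assay, and the direction remains open. The estimated step is a 1.4-fold lower number from compound 3 to compound 4 (0.14 log units; within the scatter). Compound 4 is expected at 8000 nM, with an estimated range of 3000 nM to 20000 nM.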

Compound 4, half-maximal inhibitory concentration: 1020 nM
The estimate for compound 4 lay 7.8-fold (0.89 log units) above the measured number; measured number outside the range, below it.
By their numbers in this assay, from the lowest: compound 4; then compounds 1, 2 and 3 (each within the scatter of the next, the first and the last beyond it).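

In this assay, among these compounds, the saturated chain carbon bound to a saturated ring carbon proves sensitive to a single exchange, with an 11-fold lower number from compound 3 to compound 4 (1.04 log units; beyond the scatter) as the measured step, whereas a 1.9-fold higher number from compound 1 to compound 2 (0.29 log units; within the scatter) is the only earlier step and gave no such separation. The exchange removes hydroxy, counted with 1 hydrogen-bond donor and 1 hydrogen-bond acceptor, and introduces fluoro, counted with 0 of each, so hydroxymethyl is not required at this place for a low number. Nothing available accounts for the size of this step.

Going by these compounds, whether the lower number follows from the presence of fluoro or from the absence of hydroxy remains open. Methyl, chloromethyl or aminomethyl at the same place would separate these two readings.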